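A few compounds are considered here, and "the series" means these few. Any claim that something is new, unique, unknown or untested is made for them only; others in the source may bear on it.

Measured so far in an ADME assay on microsomes from liver (Homo sapiens) for metabolic stability; on this read-out lower numbers stand for slow clearance and higher numbers for fast clearance:
- Compound 1 `Cc1ccc2[nH]c(C(=O)N[C@H]3CN(S(=O)(=O)c4ccccc4)C[C@@H]3C(=O)NC[C@H]3CCCN3)cc2c1`: < 3 mL.min-1.g-1 (a limit of the assay)
- Compound 2 `Cc1ccc2[nH]c(C(=O)N[C@H]3CN(S(=O)(=O)c4ccccc4)C[C@@H]3C(=O)N[C@@H]3CCCN(C)C3)cc2c1`: 50 mL.min-1.g-1

Going by the values given here, compound 2 gives 50 mL.min-1.g-1, the only actual number so far. Compound 3 `Cc1ccc2[nH]c(C(=O)N[C@H]3CN(S(=O)(=O)c4ccccc4)C[C@@H]3C(=O)N[C@H]3CCCNC3)cc2c1` has piperidin-3-yl in place of 1-methylpiperidin-3-yl on an amide-type nitrogen. Among the compounds with values here, one measured step bears on this change: an at least 16-fold higher number from compound 1 to compound 2 (1.22 log units; beyond the scatter). That step is large and also brought in 1-methylpiperidin-3-yl, but the group it replaced was (pyrrolidin-2-yl)methyl, so it is no clean measure of the change here. Given the large at least 16-fold higher number from compound 1 to compound 2 (1.22 log units; beyond the scatter), a lower number in this assay is expected, recovering only part of that step. The estimated step is a 5.0-fold lower number from compound 2 to compound 3 (0.70 log units; beyond the scatter). For compound 3 the estimate is 10 mL.min-1.g-1, with an expected range of 3 mL.min-1.g-1 to 30 mL.min-1.g-1.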

Compound 3, intrinsic clearance in microsomes: < 3 mL.min-1.g-1
Compound 3 ended at the assay's limit; the forecaster's own chance of this, stated with the estimate: 30%; at least 3.3-fold (0.52 log units) between middle value and limit.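

In this assay, piperidin-3-yl in place of 1-methylpiperidin-3-yl on an amide-type nitrogen gives an at least 16-fold lower number from compound 2 to compound 3 (1.22 log units; beyond the scatter). The high number of compound 2 therefore does not go with the six-membered non-aromatic ring alone, a point that the step away from (pyrrolidin-2-yl)methyl could not settle. Compound 3 gives < 3 mL.min-1.g-1, which is a limit and not a number, so only the lowest possible size of this step is known: the limit of < 3 mL.min-1.g-1 in this assay, at which 2 of the 3 values shown sit.

The step from compound 1 to compound 3 cannot be read, as both values are limits. As far as these compounds go, whether 1-ethylpiperidin-3-yl or 1-acetylpiperidin-3-yl at this place would read like compound 2 or like compound 3 remains open.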